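Nitro in Place of Hydrogen: Estimating Compound 3

The compounds below may be only part of what the source reports. "The series", "measured", "known", "first", "only" and "open" are said of these compounds alone.

Compound 1 `CC(=O)c1c(NNc2ccccc2)cc(C)oc1=O` was tested in a functional assay on the whole organism for inhibition, with Rattus norvegicus as the target, read by paw edema, with a stated time of 1 h, at a dose of 50 mg/kg (on this read-out higher numbers stand for more inhibition at the one dose given (going by the name of the read-out) and lower numbers for less inhibition), where compound 1 gives 59.5%. Compound 2 `CC(=O)c1c(NNc2ccc(Br)cc2)cc(C)oc1=O` differs from it only by bromo in place of hydrogen on an aromatic carbon; in this assay compound 2 gives 46.8%. The single measured step, a number 12.7 percentage points lower from compound 1 to compound 2 (beyond the scatter), leaves compound 1 standing highest of the two numbers shown, with compound 2 lower by a step beyond the scatter.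

Compound 3 `CC(=O)c1c(NNc2ccc([N+](=O)[O-])cc2)cc(C)oc1=O` is not yet measured; it differs from compound 1 by nitro in place of hydrogen on an aromatic carbon. Among the compounds with values here, the bromo step is the one measurement that bears on this change, as both replace a hydrogen on an aromatic carbon of compound 1, and that step was modest and downward. A step of similar size and direction is expected, and the estimated change is a number 13.5 percentage points lower from compound 1 to compound 3 (beyond the scatter). Compound 3 is therefore expected to give about 46%, within a range from 32% to 60%.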

Compound 3, a percentage reported as inhibition, in the whole organism at one dose (the size of the read-out at that dose, not a potency): 53.2%
Beside the measured number, compound 3's estimate is 7.2 percentage points below it; measured number inside the range.
By their numbers in this assay, from the lowest: compounds 2, 3 and 1 (each within the scatter of the next, the first and the last beyond it).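

In this assay, nitro on the aromatic carbon para to a large group gives a number 6.3 percentage points lower from compound 1 to compound 3 (within the scatter), so this replacement of hydrogen, unlike the bromo one, cannot be told apart from compound 1. Within the data shown here, exchanging one group for the other gives a number 6.4 percentage points higher from compound 2 to compound 3 (within the scatter), so nitro and bromo cannot be told apart at this place either, and the one step beyond the scatter, from hydrogen to bromo, does not hold for every group placed here. Nothing available explains these numbers.

The compounds shown leave open whether an amine, a carboxylic acid or a methoxy group at the same place would stay close to these numbers. They also leave open whether nitro or bromo would give similar numbers elsewhere on the ring, or at other doses and times.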